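Chloro for Fluoro: Expecting Little Change

This account rests on a few compounds, and the source may have more. Where it says the series, first, only, none or still open, it means among the compounds named here.

Of the compounds shown here, two have been measured in a functional assay on the whole organism (Tail) with Rattus norvegicus as the target, in the tail flick test, with a stated time of 60 min, at a dose of 25 mg/kg by the oral route; a lower number here means less inhibition, a higher number more inhibition at the dose given (going by the name of the read-out). Compound 1, `CC(=O)N1N=C(c2ccc(F)cc2)CC1c1cn(-c2ccccc2)nc1-c1ccc(Cl)cc1`, gives 44% in this assay. Compound 2, `Fc1ccc(C2=NN(c3ccccc3)C(c3cn(-c4ccccc4)nc3-c3ccc(F)cc3)C2)cc1`, gives 41% in this assay. These two numbers sit close together: the gap between them lies within the scatter of repeated measurements, so the two numbers are level on this evidence. The two compounds also differ in several places at once, so nothing can be learned about any single change from this pair.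

Compound 3, `Fc1ccc(C2=NN(c3ccccc3)C(c3cn(-c4ccccc4)nc3-c3ccc(Cl)cc3)C2)cc1`, has not yet been measured. Its difference from compound 2 is small: chloro in place of fluoro on an aromatic carbon. The change is a swap of one halogen for another on an aromatic carbon, with no ring added or lost and no change in hydrogen-bond donors or acceptors. Within the data shown here, no measured pair shows what this swap does here. The expected step of a number 1 percentage points higher from compound 2 to compound 3 (within the scatter) is none beyond the scatter, because compound 2 already shows 41% and nothing suggests a large move. Compound 3 is therefore expected to give 42%, with a range from 30% to 55%.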

Compound 3, a percentage reported as inhibition, in the whole organism at one dose (the size of the read-out at that dose, not a potency): 43%
Estimate against measurement, compound 3: 1 percentage points below; low and high end bracket the measured number.
By their numbers in this assay, from the lowest: compounds 2, 3 and 1 (each within the scatter of the next).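

In this assay, among these compounds, the move from 4-fluorophenyl to 4-chlorophenyl gives a number 2 percentage points higher from compound 2 to compound 3 (within the scatter) and so leaves the read-out level, which is the first direct look at this position: on this evidence, one halogen serves as well as the other here. Compound 3 also provides the single-change link to compound 1 that the earlier pair lacked: a number 1 percentage points lower from compound 1 to compound 3 (within the scatter) shows that acetyl and phenyl on the ring amine nitrogen cannot be told apart in this test. No measurement at hand bears on why either swap leaves the numbers level.

Both results come from a single oral dose, so they describe the size of the effect at that dose and not potency, and a level result between two halogens says nothing about a very different group at the same place, such as a methoxy group, an amine or a carboxylic acid. From the compounds shown here alone, on the ring amine nitrogen, it also remains open how a longer chain or a free amide hydrogen would compare with acetyl and phenyl.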